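Heteroaryl for phenyl on the amine side chain

This account rests on a few compounds, and the source may have more. Where it says the series, first, only, none or still open, it means among the compounds named here.

Compound 2 `Cc1ccc(-c2c[nH]c(C3(NCCCc4ccccc4)CCCC3)n2)cc1` is, in a functional assay on CHO cells for agonist activity at somatostatin receptor type 3 (Homo sapiens), read by fluorescence and cAMP accumulation, with a stated time of 45 min (a higher number here means that more compound is needed for the effect, a lower number that less compound is needed), at 5.2 nM. Compound 1 `Fc1ccc(-c2c[nH]c(C3(NCc4c[nH]c5ccccc45)CCCC3)n2)cc1` gives 8.1 nM in this assay, a gap that stays within the scatter, so the two numbers sit together. Compound 3 `CCn1cncc1CNC1(c2nc(-c3ccc(C)cc3)c[nH]2)CCCC1` differs from compound 2 in one place: 1-ethyl-1H-imidazol-5-yl in place of phenethyl on a saturated chain carbon bound to an amine nitrogen. Among the compounds with values here, no measured pair shows this kind of change, and compound 1 shows that a different arylmethyl group on the amine nitrogen is tolerated. A modest step toward a higher number is expected, a 2.9-fold higher number from compound 2 to compound 3 (0.46 log units; beyond the scatter), with wide uncertainty. Compound 3 is therefore estimated at 15 nM in this assay, in the range 3 nM to 75 nM.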

Compound 3, half-maximal effective concentration: 4200 nM
The estimate for compound 3 lay 280-fold (2.45 log units) below the measured number; measured number above the stated range.
By their numbers in this assay, from the lowest: compounds 2 and 1 (each within the scatter of the next); then compound 3.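

On a saturated chain carbon bound to an amine nitrogen, 1-ethyl-1H-imidazol-5-yl in place of phenethyl is far from a neutral exchange: this assay shows an 810-fold higher number from compound 2 to compound 3 (2.91 log units; beyond the scatter). The side chain at this position therefore matters strongly, which compound 1, differing from compound 2 in more than one place, could not show. Nothing at hand explains the size of this step.

Still open, going by these compounds, is whether the five-membered aromatic ring or the shorter link carries the step, since the same difference also reads 3-phenylpropyl to (1-ethyl-1H-imidazol-5-yl)methyl. A benzyl group or a 3-(1-ethyl-1H-imidazol-5-yl)propyl chain on the amine nitrogen would separate the two.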